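A few compounds are considered here, and "the series" means these few. Any claim that something is new, unique, unknown or untested is made for them only; others in the source may bear on it.

Measured so far, in a functional assay on MDA-MB-231 cells (Homo sapiens) for cytotoxicity, read by sulforhodamine B assay, with a stated time of 72 h; on this read-out higher numbers stand for weaker inhibition of growth and lower numbers for stronger inhibition of growth:
Compound 1 `O=C(Nc1ccccc1C(F)(F)F)C1CCc2ccccc2N1C(=O)c1ccccc1` gives 5290 nM.
Compound 2 `O=C(Nc1ccccc1)C1CCc2ccccc2N1` gives 108000 nM.
Compound 3 `O=C(Nc1ccccc1C(F)(F)F)C1CCc2ccccc2N1` gives 45500 nM.

Compound 3 stands second highest of these three numbers: compound 2 gives the higher number, with the gap a 2.4-fold lower number from compound 2 to compound 3 (0.38 log units; beyond the scatter), while compound 1 gives the lowest, the gap being an 8.6-fold higher number from compound 1 to compound 3 (0.93 log units; beyond the scatter) in the other direction. Compound 4 `CC(=O)N1c2ccccc2CCC1C(=O)Nc1ccccc1C(F)(F)F` differs from compound 3 in one place: acetyl in place of hydrogen on a nitrogen on an aromatic ring in a ring.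

The measured step that bears on this change is an 8.6-fold higher number from compound 1 to compound 3 (0.93 log units; beyond the scatter), in which hydrogen in place of benzoyl on the same nitrogen raised the number markedly; read in reverse, an acyl group on that nitrogen went with a clearly lower number. Acetyl is a different acyl group from benzoyl, and no measured pair shows acetyl on this nitrogen, so the size of the effect is uncertain. The expectation in this assay is therefore a downward step from compound 3, probably not as large as the one seen with benzoyl, namely a 3.8-fold lower number from compound 3 to compound 4 (0.58 log units; beyond the scatter). Compound 4 is thus expected to give about 12000 nM, within a range from 3500 nM to 40000 nM.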

Compound 4, concentration for 50% growth inhibition: > 80000 nM
Compound 4: a limit, no number; the forecaster's own chance of this, stated with the estimate: 5%; middle value at least 6.6-fold (0.82 log units) away from the limit.
By their numbers in this assay, from the lowest: compound 1; then compound 3; then compound 2.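

Compound 4 gives > 80000 nM in this assay, which is a limit of the assay and not a number: the limit of > 80000 nM in this assay, at which 1 of the 4 values shown sits. Acetyl on this nitrogen did not bring the drop that the benzoyl compound had suggested, since the result is an at least 1.7-fold higher number from compound 3 to compound 4 (0.24 log units; that floor lies within the scatter), so no fall appears, though a real rise over hydrogen is not established either. Changing only the group on the carbonyl carbon gives an at least 15-fold higher number from compound 1 to compound 4 (1.17 log units; beyond the scatter), so among these compounds the lower number goes with benzoyl in particular, and not with just any acyl group on this nitrogen.

As far as these compounds go, it remains open whether a longer chain such as butanoyl, or a different ring such as cyclohexanecarbonyl, would bring the number down as benzoyl does. From the compounds shown here alone, it is also open whether benzoyl would give a similar step on compound 2, which has hydrogen in place of the trifluoromethyl.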